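Methyl step from compound 2: working notes

The source may report more compounds than this note shows. Statements on the series, on what has been measured and on what is new or still open speak of the compounds shown alone.

Compound 1 (`O=C(CCCCCCN1C(=O)/C(=N\O)c2cc(F)ccc21)NO`) gives 1720 nM in a functional assay on ASPC1 cells (Homo sapiens) for antiproliferative activity, read by sulforhodamine B assay, with a stated time of 48 h (on this read-out lower numbers stand for stronger inhibition and higher numbers for weaker inhibition), as one of two reference points in the series. Compound 2 (`CO/N=C1/C(=O)N(CCCCCCC(=O)NO)c2ccccc21`) gives 1220 nM in this assay as the other. The two values lie within the usual scatter of each other, so compound 2 stands level with compound 1 and no ranking can be drawn.

Compound 3 (`CO/N=C1/C(=O)N(CCCCCCC(=O)NO)c2ccc(C)cc21`) follows from compound 2 with methyl in place of hydrogen on an aromatic carbon and has no number yet. Going by the values given here, the series holds no measured step between compounds that differ in one place, so the size of this step cannot be read from the data. The expectation therefore rests on compound 2 at 1220 nM as the closest measured structure, and no step beyond the scatter is expected in this assay in either direction. The estimated step of a 1.1-fold lower number from compound 2 to compound 3 (0.04 log units; within the scatter) stays within the scatter. For compound 3 the expected value is 1100 nM with an estimated range from 500 nM to 2400 nM for now.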

Compound 3, half-maximal inhibitory concentration: 5480 nM
For compound 3 the middle estimate is 5.0-fold (0.70 log units) below the measured one, and the stated range ends below it.
By their numbers in this assay, from the lowest: compounds 2 and 1 (each within the scatter of the next); then compound 3.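

In this assay the series now has its first step between compounds that differ in one place, a 4.5-fold higher number from compound 2 to compound 3 (0.65 log units; beyond the scatter), and it lies beyond the scatter on the side of weaker inhibition. This position, on an aromatic carbon of the six-membered aromatic ring, is therefore not indifferent to change: methyl in place of hydrogen adds only one heavy atom, with no hydrogen-bond donors or acceptors, yet the number moves. Compound 1 and compound 2 could not show this, as they differ in more than one place and stand within the scatter of each other, and nothing available on the series explains the size or direction of the step.

As far as these compounds go, it remains open whether this response is particular to methyl or holds for other groups at the same carbon, such as chlorine, an amine, a carboxylic acid or a longer chain like ethyl. From the compounds shown here alone, it is equally open whether methyl on the other aromatic carbons of the ring would give a step of the same direction, so the reading holds for this single pair only.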